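The source may report more compounds than this note shows. Statements on the series, on what has been measured and on what is new or still open speak of the compounds shown alone.

In an ADME assay on HepG2 cells (Homo sapiens) for cytotoxicity, read by CellTiter-Glo and resazurin assay, with a stated time of 72 h (a lower number here means that less compound is needed, a higher number that more compound is needed for the effect), the measured compounds are:
- Compound 1 (`COc1cccc(-c2ccc(C(=O)N(Cc3cccc(OCCCCCC(=O)O)c3)C(C)C)cc2)c1`) gives > 26000 nM (a limit)
- Compound 2 (`COc1cc(F)cc(-c2ccc(C(=O)N(Cc3cccc(OCCCCCC(=O)O)c3)C(C)C)cc2)c1`) gives > 26000 nM (a limit)

Compound 2 has only a limit to show (> 26000 nM). Compound 3 (`CC(C)N(Cc1cccc(OCCCCCC(=O)O)c1)C(=O)c1ccc(-c2cccc(Br)c2)cc1`) has 3-bromophenyl in place of 3-fluoro-5-methoxyphenyl on an aromatic carbon, para to a large group (3-bromophenyl in place of 3-fluoro-5-methoxyphenyl on an aromatic carbon). Going by the values given here, the one measured step (a step that the two limits leave unreadable from compound 1 to compound 2) gives no size to carry over. Among the compounds with values here, with the limit of > 26000 nM in this assay, at which 2 of the 2 values shown sit, as the only evidence, no step beyond the scatter is expected in this assay for compound 3. The expected step is small (a step that the limit leaves unreadable from compound 2 to compound 3). Compound 3 is estimated at 30000 nM with 15000 nM to 60000 nM as the expected range.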

Compound 3, half-maximal effective concentration: > 26000 nM
Compound 3 gave a limit, no number (the forecaster's own chance of this, stated with the estimate: 75%); the middle value does not contradict the limit.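

Compound 1, compound 2 and compound 3 each give only a limit, so no step between them can be read: the limit of > 26000 nM in this assay, at which 3 of the 3 values shown sit.

The compounds shown leave open whether any of these substitutions changes the half-maximal effective concentration in this assay.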